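The source may hold more compounds than are shown below. What is called first, only, known or untested is meant among the compounds shown, and "the series" means these compounds.

Compound 3 `COc1cc2ncnc(Nc3ccc(OC(F)(F)F)cc3)c2cc1OCCCCC(=O)Nc1ccc(S(N)(=O)=O)cc1` belongs to a small set built on one shared core, in which the group on the nitrogen of the aromatic ring is varied. In a functional assay on A549 cells (Homo sapiens) for antiproliferative activity, read by MTT assay, with a stated time of 72 h (a lower number here means a stronger inhibitor, a higher number a weaker inhibitor), compound 1 `COc1cc2ncnc(Nc3ccc(F)c(Cl)c3)c2cc1OCCCCC(=O)Nc1ccc(S(N)(=O)=O)cc1` gives 15500 nM. Compound 2 `COc1cc2ncnc(Nc3ccc(Cl)cc3)c2cc1OCCCCC(=O)Nc1ccc(S(N)(=O)=O)cc1` reaches only a limit of the assay, > 40000 nM. Compound 3 likewise reaches only a limit, > 40000 nM. Against compound 1 this is an at least 2.5-fold higher number from compound 1 to compound 3 (0.41 log units; beyond the scatter), and the same holds for an at least 2.5-fold higher number from compound 1 to compound 2 (0.41 log units; beyond the scatter). Between the two limits, a step that the two limits leave unreadable from compound 2 to compound 3.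

Compound 4 `COc1cc2ncnc(Nc3ccc(C(F)(F)F)cc3)c2cc1OCCCCC(=O)Nc1ccc(S(N)(=O)=O)cc1` differs from compound 3 in one place: trifluoromethyl in place of trifluoromethoxy on an aromatic carbon. Among the compounds with values here, no measured step covers this exchange directly; the nearest one, from compound 2 to compound 3, cannot be read, since it joins two values that both sit at the limit of > 40000 nM in this assay, at which 2 of the 3 values shown sit. Compound 4 is therefore expected to stay near the limit at which compound 3 stands, with a step that the limit leaves unreadable from compound 3 to compound 4 as the estimated step. In this assay compound 4 is expected to give about 45000 nM, between 15000 nM and 120000 nM.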

Compound 4, half-maximal inhibitory concentration: 14800 nM
The estimate for compound 4 lay 3.0-fold (0.48 log units) above the measured number; the measured number lies below the stated range.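

Within the data shown here, at this position, the exchange of trifluoromethoxy for trifluoromethyl gives the first readable change among the groups that stand alone on the ring: in this assay there is an at least 2.7-fold lower number from compound 3 to compound 4 (0.43 log units; beyond the scatter), and the exchange of chloro for trifluoromethyl likewise gives an at least 2.7-fold lower number from compound 2 to compound 4 (0.43 log units; beyond the scatter). A single group at this place can therefore match the 3-chloro-4-fluorophenyl pattern, with a 1.0-fold lower number from compound 1 to compound 4 (0.02 log units; within the scatter). Such a single group does not always do so, as compound 2 and compound 3 go against this.

On these data alone, whether chloro and trifluoromethoxy differ at all stays open, since the step between compound 2 and compound 3 cannot be read: the limit of > 40000 nM in this assay, at which 2 of the 4 values shown sit. Also open, as far as these compounds go, is how a nitrile, an amine or a carboxylic acid would behave at this position.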